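Cyclopentyl in place of 5-chloropyridin-2-yl on the amide

This account rests on a few compounds, and the source may have more. Where it says the series, first, only, none or still open, it means among the compounds named here.

In an in vitro ADME assay on microsomes from liver (Mus musculus) for pharmacokinetics, read by LC-MS, with a stated time of 10 min, tested at 1 uM (on this read-out lower numbers stand for slow clearance and higher numbers for fast clearance), compound 1 (`CN1C[C@H](C(=O)Nc2ccc(C#N)cc2)[C@@H](c2ccc(/C=C/C(=O)Nc3ccccc3N)cc2)C1`) gives 35 mL/min/kg and compound 2 (`Cc1cc(NC(=O)[C@H]2CN(C)C[C@@H]2c2ccc(/C=C/C(=O)Nc3ccccc3N)cc2)ccc1Cl`) gives 65 mL/min/kg on the same shared core. Compound 3 (`CN1C[C@H](C(=O)Nc2ccc(Cl)cn2)[C@@H](c2ccc(/C=C/C(=O)Nc3ccccc3N)cc2)C1`) gives 31 mL/min/kg and so stands level with compound 1 and under compound 2. Compound 4 (`CN1C[C@H](C(=O)NC2CCCC2)[C@@H](c2ccc(/C=C/C(=O)Nc3ccccc3N)cc2)C1`) has not yet been measured. It carries cyclopentyl in place of 5-chloropyridin-2-yl on an amide-type nitrogen. Within the data shown here, the only guidance comes from swaps at this same nitrogen, and all of them exchange one aromatic ring for another. They are small: a 1.1-fold lower number from compound 1 to compound 3 (0.05 log units; within the scatter) and a 1.9-fold higher number from compound 1 to compound 2 (0.27 log units; within the scatter) stay inside the scatter, while a 2.1-fold lower number from compound 2 to compound 3 (0.32 log units; beyond the scatter) only just passes it. Among the measured compounds shown here, no measured compound has a non-aromatic ring here, so the direction remains open and the range must stay wide. The expected step is a 1.1-fold higher number from compound 3 to compound 4 (0.05 log units; within the scatter) and so none beyond the scatter. Compound 4 is estimated at 35 mL/min/kg with 16 mL/min/kg to 75 mL/min/kg as its expected range.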

Compound 4, clearance: 61 mL/min/kg
The estimate for compound 4 lay 1.7-fold (0.24 log units) below the measured number, and the stated range covers the measured number.
By their numbers in this assay, from the lowest: compounds 3, 1, 4 and 2 (each within the scatter of the next, the first and the last beyond it).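

Among these compounds, compound 4 is the first compound here with a non-aromatic ring on the amide-type nitrogen, and in this assay this swap gives a 2.0-fold higher number from compound 3 to compound 4 (0.29 log units; within the scatter) and a 1.7-fold higher number from compound 1 to compound 4 (0.24 log units; within the scatter) and a 1.1-fold lower number from compound 2 to compound 4 (0.03 log units; within the scatter). An aromatic ring at this place is therefore not required for a number inside the range that the three aromatic compounds span, and none of these steps from an aromatic ring to cyclopentyl passes the usual scatter. Nothing measured here explains these numbers.

Whether any ring is needed at all remains open, as the compounds shown include no open-chain group such as a butyl chain and no ring carrying an amine, such as piperidine. Whether cyclopentyl would give a similar result on a different core is also unknown.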